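The compounds below may be only part of what the source reports. "The series", "measured", "known", "first", "only" and "open" are said of these compounds alone.

Measured so far in an ADME assay on microsomes from liver (Mus musculus) for metabolic stability, with a stated time of 10 min (on this read-out lower numbers stand for a less stable compound and higher numbers for a more stable compound), are three compounds:
- compound 1 `CC(=O)N1CCC(O)(C(=O)N2CC[C@](c3ccc(C(OCc4c(F)cccc4F)(C(F)(F)F)C(F)(F)F)cc3)(S(=O)(=O)c3ccc(F)cc3)C2)CC1` gives 69%
- compound 2 `O=C(C1CCOCC1)N1CC[C@](c2ccc(C(OCc3c(F)cccc3F)(C(F)(F)F)C(F)(F)F)cc2)(S(=O)(=O)c2ccc(F)cc2)C1` gives 29%
- compound 3 `CC(=O)N1CCN(C(=O)N2CC[C@](c3ccc(C(OCc4c(F)cccc4C#N)(C(F)(F)F)C(F)(F)F)cc3)(S(=O)(=O)c3ccc(F)cc3)C2)CC1` gives 1%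

Compound 2 holds the second highest of these three numbers, with compound 1 higher and compound 3 lower. The next compound to be measured is compound 4 `O=C(O)C1CCN(C(=O)N2CC[C@](c3ccc(C(OCc4c(F)cccc4F)(C(F)(F)F)C(F)(F)F)cc3)(S(=O)(=O)c3ccc(F)cc3)C2)CC1`, which keeps the shared core of compound 2. Its change is 4-carboxypiperidin-1-yl in place of oxan-4-yl on a carbonyl carbon.

Going by the values given here, one measured step concerns this same place: a number 40 percentage points lower from compound 1 to compound 2 (beyond the scatter). It is large and beyond the usual scatter, so a change in this group alone can move the read-out strongly. Among the compounds with values here, compound 3 differs from compound 2 in more than one place and gives no clean step, but compound 3 at 1% is a warning that a low number remains possible. Within the data shown here, no measured compound carries the incoming group itself. A large rise is still expected, guided only by compound 1 at 69%, and the margin must stay wide. The estimate means a number 36 percentage points higher from compound 2 to compound 4 (beyond the scatter) as the expected step. For compound 4 the estimated value is 65%, with an expected range from 35% to 92%.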

Compound 4, percent of the compound remaining: 84%
Compound 4: the middle estimate sits 19 percentage points below what was measured; measured number inside the range.
By their numbers in this assay, from the lowest: compound 3; then compound 2; then compound 1; then compound 4.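

In this assay, putting 4-carboxypiperidin-1-yl in place of oxan-4-yl on the carbonyl carbon gives a number 55 percentage points higher from compound 2 to compound 4 (beyond the scatter) and marks a large gain, so this position tolerates a ring carrying a free carboxy group without any loss on this read-out. The earlier compounds shown here showed only that 1-acetyl-4-hydroxypiperidin-4-yl stood well above oxan-4-yl, whereas the new comparison gives a number 15 percentage points higher from compound 1 to compound 4 (beyond the scatter) as a modest step, so a high number at this position does not depend on the acetyl and hydroxy groups of compound 1. Nothing available here explains why these groups differ in this way.

As far as these compounds go, the change from compound 2 to compound 4 swaps the oxygen ring joined through carbon for a ring joined through nitrogen and adds the carboxy group in a single move, so the share of each remains open. A plain piperidin-1-yl on the same carbonyl carbon, or one carrying a methyl ester or an amine where compound 4 has its carboxylic acid, would help separate the two contributions.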